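Sulfonyl exchange at the limit: toward compound 4

The source may report more compounds than this note shows. Statements on the series, on what has been measured and on what is new or still open speak of the compounds shown alone.

In a functional assay on HCT-116 cells (Homo sapiens) for antiproliferative activity, read by MTT assay, with a stated time of 48 h (on this read-out lower numbers stand for stronger inhibition and higher numbers for weaker inhibition), compound 1 `CCNC(=O)Nc1nc(-c2ccc(OCC)cc2)c(-c2cc(OC)c(OC)c(OC)c2)s1` gives 22.1 nM. Compound 2 `CCOc1ccc(-c2nc(NS(=O)(=O)c3ccccc3C(F)(F)F)sc2-c2cc(OC)c(OC)c(OC)c2)cc1` reads > 5000 nM, which is a limit. Compound 3 `CCOc1ccc(-c2nc(NS(=O)(=O)c3ccc([N+](=O)[O-])cc3OC)sc2-c2cc(OC)c(OC)c(OC)c2)cc1` reads > 5000 nM, also only a limit, so it has no exact position. Compound 4 `CCOc1ccc(-c2nc(NS(=O)(=O)c3ccc(OC)c(F)c3)sc2-c2cc(OC)c(OC)c(OC)c2)cc1` carries 3-fluoro-4-methoxyphenyl in place of 2-methoxy-4-nitrophenyl on a sulfonyl sulfur. The nearest measured change on that sulfur is a step that the two limits leave unreadable from compound 2 to compound 3. Both of its ends are limits: the limit of > 5000 nM in this assay, at which 2 of the 3 values shown sit. It therefore offers no size to carry over, and no clear step is expected in this assay. The expected change is a number no higher from compound 3 to compound 4 (the limit leaves the size open). For compound 4 the estimate is 5000 nM, with an expected range of 800 nM to 20000 nM.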

Compound 4, half-maximal inhibitory concentration: > 5000 nM
Compound 4 gave a limit, no number (the forecaster's own chance of this, stated with the estimate: 65%); the middle value sits exactly at the limit.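

In this assay the 3-fluoro-4-methoxyphenyl of compound 4 carries neither the nitro nor the trifluoromethyl group of the two earlier aryl groups on the sulfonyl sulfur, yet its reading is again only a limit: the limit of > 5000 nM in this assay, at which 3 of the 4 values shown sit.

The steps among the three sulfonyl compounds cannot be read. Exchanging ethylcarbamoyl for (3-fluoro-4-methoxyphenyl)sulfonyl on a nitrogen on an aromatic ring gives an at least 220-fold higher number from compound 1 to compound 4 (2.35 log units; beyond the scatter).

Open, as far as these compounds go, is whether a methylsulfonyl group in place of the aryl groups, or a propylcarbamoyl group in place of ethylcarbamoyl, gives a number rather than a limit.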